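A few compounds are considered here, and "the series" means these few. Any claim that something is new, unique, unknown or untested is made for them only; others in the source may bear on it.

Compound 1, `COc1cc(-c2cc(/C=C/C(=O)c3ccc(N)cc3)[nH]n2)cc(OC)c1OC`, in a functional assay on MOLT-4 cells (Homo sapiens) for cytotoxicity, read by sulforhodamine B assay, with a stated time of 48 h, tested at 0.01 uM (a lower number here means a stronger effect, a higher number a weaker effect of the compound at the concentration tested), gives 101%.
Compound 2, `COc1cc(-c2cc(/C=C/C(=O)c3ccc(Cl)c(Cl)c3)[nH]n2)cc(OC)c1OC`, gives 98%.
Compound 3, `COc1ccc(C(=O)/C=C/c2cc(-c3cc(OC)c(OC)c(OC)c3)n[nH]2)cc1OC`, gives 102%.

All three share one core and differ only in the aromatic ring attached to the carbonyl carbon. The steps among them are small: a number 3 percentage points lower from compound 1 to compound 2 (within the scatter), a number 1 percentage points higher from compound 1 to compound 3 (within the scatter) and a number 4 percentage points higher from compound 2 to compound 3 (within the scatter). Compound 3 carries the highest of the three numbers, but it sits within the scatter of both others, so no order among them can be read from these values.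

Compound 4, `COc1ccc(C(=O)/C=C/c2cc(-c3cc(OC)c(OC)c(OC)c3)n[nH]2)cc1`, is the next variation on the same ring: hydrogen in place of methoxy on an aromatic carbon. Going by the values given here, no measured step removes a methoxy group in this way; the three steps that do exist all swap substituents on that ring and none of them moves the number beyond the scatter. On that basis the step from compound 3 to compound 4 is expected to be a number 2 percentage points lower from compound 3 to compound 4 (within the scatter). Compound 4 is therefore estimated at 100%, in a range from 88% to 110%.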

Compound 4, a percentage reported as activity, at one concentration (the size of the read-out at that concentration, not a potency): 103%
Compound 4: middle estimate off by 3 percentage points, on the low side; measured number inside the range.
By their numbers in this assay, from the lowest: compounds 2, 1, 3 and 4 (each within the scatter of the next).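

Within this assay the change from 3,4-dimethoxyphenyl to 4-methoxyphenyl gives a number 1 percentage points higher from compound 3 to compound 4 (within the scatter) and is the first step here that removes a group from this ring instead of swapping one group for another. The comparisons with the other two rings read the same way, with a number 5 percentage points higher from compound 2 to compound 4 (within the scatter) and a number 2 percentage points higher from compound 1 to compound 4 (within the scatter) as well, so at this single concentration 4-methoxyphenyl cannot be told apart from 3,4-dimethoxyphenyl, 3,4-dichlorophenyl or 4-aminophenyl. No further measurement is available to explain this result.

Going by these compounds, whether a hydroxyl group, a carboxylic acid or a longer chain such as ethoxy on this ring would move the number remains open. So does whether these compounds would separate at higher concentrations, or with changes elsewhere on the shared core.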